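From methyl to ethyl on the shared core

The source may report more compounds than this note shows. Statements on the series, on what has been measured and on what is new or still open speak of the compounds shown alone.

The compounds measured so far:
Compound 1, `Cc1cccc(NC(=O)N[C@H](C)c2ccccc2)c1`, gives 47%.
Compound 2, `Cc1cccc(NC(=O)N[C@@H](C)c2ccccc2)c1`, gives 100%.
Compound 3, `Cc1ccc(NC(=O)N[C@H](C)c2ccccc2)cc1`, gives 64%.
Compound 4, `CCc1cccc(NC(=O)N[C@H](C)c2ccccc2)c1`, has not been measured yet.

In an ADME assay on the whole organism with Oryza sativa as the target, tested at 10 uM (on this read-out higher numbers stand for a weaker effect at the one concentration tested and lower numbers for a stronger effect), compound 1 gives 47%, the lowest of the three numbers; compound 3 gives 64%, a higher number beyond the scatter, and compound 2 gives 100%, the furthest away. Among the measured compounds shown here, the only step in which a single thing changes is a number 53 percentage points higher from compound 1 to compound 2 (beyond the scatter), a large step that can be attributed to the fact that compounds 1 and 2 differ only in the configuration as drawn. Compound 4 differs from compound 1 by methyl in place of hydrogen on a saturated chain carbon bound to an aromatic carbon. For the measured compounds named here, none of the measured steps touches this part of the core of compound 1, so no measured step bears directly on the change, and the comparison of compound 1 with compound 3 shows only how two placings of the methyl differ. The author therefore expects no step beyond the scatter, a number 3 percentage points higher from compound 1 to compound 4 (within the scatter). Compound 4 is estimated at 50%, within a range from 25% to 80%.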

Compound 4, a percentage reported as activity, at one concentration (the size of the read-out at that concentration, not a potency): 36%
Beside the measured number, compound 4's estimate is 14 percentage points above it, and the stated range covers the measured number.
By their numbers in this assay, from the lowest: compound 4; then compound 1; then compound 3; then compound 2.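

In this assay, the change from methyl to ethyl gives a number 11 percentage points lower from compound 1 to compound 4 (beyond the scatter), a modest step towards a stronger effect at the one concentration tested. Among the compounds shown here, this is the first step that alters the group itself at this place on the shared core, whereas the earlier compounds showed only a change of configuration and two placings of the methyl, so the place is now known to respond to a change of chain. Nothing in the available evidence bears on why the ethyl group gives this result.

The compounds shown leave open whether a longer chain such as propyl, or a branched group such as isopropyl, would carry the number further in the same direction. They also leave open whether the change from methyl to ethyl would give a similar step in the opposite configuration, as drawn in compound 2.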